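Compound 3 and the methoxycarbonyl swap

The compounds below may be only part of what the source reports. "The series", "measured", "known", "first", "only" and "open" are said of these compounds alone.

Measured so far in a functional assay for inhibition, with Homo sapiens as the target (on this read-out higher numbers stand for weaker inhibition and lower numbers for stronger inhibition), with these results
compound 1 `COc1cc(OC)c(C(=O)/C=C/c2nccn2C)c(OC)c1` gives 3800 nM
compound 2 `COc1cccc(OC)c1C(=O)/C=C/c1ccccc1` gives 1150 nM
compound 3 `COc1ccccc1C(=O)/C=C/c1ccccc1` gives 2230 nM

In this assay compound 3 gives 2230 nM and so lies within the usual scatter of both other compounds. The next compound to be tested is compound 4 `COC(=O)c1ccccc1C(=O)/C=C/c1ccccc1`, which has methoxycarbonyl in place of methoxy on an aromatic carbon, ortho to a large group (methoxycarbonyl in place of methoxy on an aromatic carbon).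

Among the measured compounds shown here, only one measured step offers a close comparison. Replacing a methoxy with hydrogen gives a 1.9-fold higher number from compound 2 to compound 3 (0.29 log units; within the scatter), so that change stays within the scatter. It is only a loose guide, since it puts hydrogen rather than methoxycarbonyl in place of methoxy, and at a different spot on the molecule. For the measured compounds named here, no measured compound carries methoxycarbonyl. Compound 1 differs from compound 3 in several places, so it offers no clean comparison.

On this thin evidence, no step beyond the scatter is expected in this assay, and no direction can be firmly predicted. The expected change is a 1.3-fold higher number from compound 3 to compound 4 (0.10 log units; within the scatter), which is an estimate. Compound 4 is estimated at 2800 nM, with an expected range from 1000 nM to 8000 nM.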

Compound 4, half-maximal inhibitory concentration: 1950 nM
Estimate against measurement, compound 4: 1.4-fold (0.16 log units) above, within the range that was stated.
By their numbers in this assay, from the lowest: compounds 2, 4, 3 and 1 (each within the scatter of the next, the first and the last beyond it).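

Among the compounds shown here, compound 4 is the first compound here to carry methoxycarbonyl, and in this assay this swap gives a 1.1-fold lower number from compound 3 to compound 4 (0.06 log units; within the scatter) and so leaves the read-out within the usual scatter. For the compounds shown here, the only earlier step replaced a methoxy with hydrogen, whereas this one places a larger group on an aromatic carbon ortho to a large group: methoxycarbonyl has 4 heavy atoms against 2 for methoxy, 2 hydrogen-bond acceptors against 1, and a double bond outside aromatic rings, yet none of these differences comes with a step beyond the scatter in this single pair. Nothing measured here explains why the read-out stays within the scatter, and no separate data on the properties of either group accompany this result.

From the compounds shown here alone, what remains open is whether this place would accept other kinds of group equally well, such as a carboxylic acid, an amine, or a longer chain like ethoxycarbonyl. Going by these compounds, it is also open whether the same swap would stay within the scatter on the core of compound 1, which differs from compound 3 in several places.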